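The compounds below may be only part of what the source reports. "The series", "measured", "known", "first", "only" and "open" are said of these compounds alone.

Measured so far:
Compound 1 `Cc1ccc(SCc2ccc(C(=O)Nc3ccccc3N)cc2)cc1` gives 3270 nM
Compound 2 `Nc1ccccc1NC(=O)/C=C/c1ccc(CSc2cccc3ccccc23)cc1` gives 830 nM
Compound 3 `Nc1ccccc1NC(=O)c1ccc(CSCCc2ccccc2)cc1` gives 3250 nM

In a functional assay on A549 cells (Homo sapiens) for antiproliferative activity, read by CCK-8 assay, with a stated time of 72 h (on this read-out lower numbers stand for stronger inhibition and higher numbers for weaker inhibition), compound 3 gives 3250 nM and sits within the scatter of compound 1, while compound 2 reads lower at 830 nM by a margin beyond the scatter. Compound 4 `Cc1cc(C)cc(SCc2ccc(C(=O)Nc3ccccc3N)cc2)c1` has 3,5-dimethylphenyl in place of phenethyl on a sulfur, and the counted difference is 3,5-dimethylphenyl in place of phenethyl on a sulfur in full. For the measured compounds named here, the one measured step that bears on this swap is a 1.0-fold lower number from compound 1 to compound 3 (0.00 log units; within the scatter) and it concerns the same sulfur, where 4-methylphenyl gave way to phenethyl. That step stayed within the scatter, so none beyond the scatter is expected here. The estimated step is a 1.2-fold lower number from compound 3 to compound 4 (0.06 log units; within the scatter) in this assay for this change. For compound 4 the expected value is 2800 nM with an estimated range from 1200 nM to 6500 nM as its limits.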

Compound 4, half-maximal inhibitory concentration: 2890 nM
Estimate against measurement, compound 4: 1.0-fold (0.01 log units) below; the measured number falls inside the stated range.
By their numbers in this assay, from the lowest: compound 2; then compounds 4, 3 and 1 (each within the scatter of the next).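

With 3,5-dimethylphenyl on the sulfur, this assay shows a 1.1-fold lower number from compound 3 to compound 4 (0.05 log units; within the scatter) and a 1.1-fold lower number from compound 1 to compound 4 (0.05 log units; within the scatter) on the same core. Three carbon groups of different shape on this sulfur, an aromatic ring with one methyl, one with two methyls and a phenethyl chain, therefore cannot be told apart here. No measurement at hand explains this sameness. On these data alone, what remains open is whether an amine or a carboxylic acid on one of these groups would move the number beyond the scatter. As far as these compounds go, a simple methyl on the sulfur also remains untested.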